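This account rests on a few compounds, and the source may have more. Where it says the series, first, only, none or still open, it means among the compounds named here.

Measured so far in a functional assay on MCF7 cells (Homo sapiens) for antiproliferative activity, read by MTT assay, with a stated time of 48 h; a lower number here means a stronger inhibitor, a higher number a weaker inhibitor:
compound 1 `CCNCC(=O)Nc1cc(OC)ccc1C(=O)c1ccc2c(c1)C=CC(C)(C)O2` gives 6310 nM
compound 2 `COc1ccc(C(=O)c2ccc3c(c2)C=CC(C)(C)O3)c(NC(=O)CN(C)C)c1` gives 3560 nM
compound 3 `CCNCC(=O)Nc1cc(OC)ccc1C(=O)c1cc(OC)c(OC)c(OC)c1` gives 1050 nM

Compound 1 and compound 2 share a core and differ only by dimethylamino in place of ethylamino on a saturated chain carbon bound to a carbonyl carbon. That change produced a 1.8-fold lower number from compound 1 to compound 2 (0.25 log units; within the scatter). Compound 3 has the lowest number of the three; how its core differs from the core of compound 1 is not broken down here.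

Compound 4 `COc1ccc(C(=O)c2cc(OC)c(OC)c(OC)c2)c(NC(=O)CN(C)C)c1` has not yet been measured. It differs from compound 3 by dimethylamino in place of ethylamino on a saturated chain carbon bound to a carbonyl carbon, at the same place as before, so this is the same change already seen between compound 1 and compound 2. The expected step is a 1.8-fold lower number from compound 3 to compound 4 (0.24 log units; within the scatter), which rests on the earlier step of a 1.8-fold lower number from compound 1 to compound 2 (0.25 log units; within the scatter). Compound 4 is therefore estimated at 600 nM, most likely between 250 nM and 1500 nM.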

Compound 4, half-maximal inhibitory concentration: 790 nM
The estimate for compound 4 lay 1.3-fold (0.12 log units) below the measured number; measured number inside the range.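

In this assay, putting dimethylamino in place of ethylamino gave a 1.3-fold lower number from compound 3 to compound 4 (0.12 log units; within the scatter) on the second core, so this swap behaved alike on both cores shown, and the two steps do not differ: the same change on two cores in this assay, a 1.8-fold lower number (0.25 log units; within the scatter) from compound 1 to compound 2 and a 1.3-fold lower number (0.12 log units; within the scatter) from compound 3 to compound 4, 1.3-fold (0.13 log units) apart, within the scatter of two such steps

Each step lies within the usual scatter of repeated measurements, so neither one shows that the swap itself alters antiproliferative activity. Two cores also cannot show that the same would hold on any further core in this series.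

The compounds shown leave open whether a larger swap at this place would give a step beyond the scatter. Candidates include a plain amino group, a longer chain such as propylamino, or a ring amine such as piperidine.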